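Adding a Heptyl Chain to Compound 3

The compounds below may be only part of what the source reports. "The series", "measured", "known", "first", "only" and "open" are said of these compounds alone.

Compound 3 `Cc1ccc(S(=O)(=O)N2CCC(Br)CC2)cc1` was tested in a functional assay on SW1573 cells (Homo sapiens) for antiproliferative activity, read by sulforhodamine B assay, with a stated time of 48 h; on this read-out higher numbers stand for weaker inhibition of growth and lower numbers for stronger inhibition of growth. In this assay compound 3 gives only a limit, > 100000 nM. Compound 1 `Cc1ccc(S(=O)(=O)N2CCC(Cl)CC2)cc1` also gives only a limit, > 100000 nM. Compound 2 `Cc1ccc(S(=O)(=O)N2CC[C@@H](Cl)C[C@@H]2C2CCCCC2)cc1` gives 53000 nM; the bromo-for-chloro step that the two limits leave unreadable from compound 1 to compound 3 cannot be read, since both ends sit at the limit of > 100000 nM in this assay, at which 2 of the 3 values shown sit. Compound 4 `CCCCCCC[C@H]1C[C@H](Br)CCN1S(=O)(=O)c1ccc(C)cc1` differs from compound 3 by heptyl in place of hydrogen on a saturated ring carbon. Going by the values given here, the only comparable measured step is an at least 1.8-fold lower number from compound 1 to compound 2 (0.27 log units; that floor lies within the scatter), where a cyclohexyl likewise replaced hydrogen on the saturated ring. A similar move from the limit to a measurable number is expected here, giving an estimated at least 2.0-fold lower number from compound 3 to compound 4 (0.30 log units; that floor lies within the scatter). Compound 4 is therefore expected at about 50000 nM, within a range from 15000 nM to 150000 nM.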

Compound 4, concentration for 50% growth inhibition: > 100000 nM
Compound 4 was reported as a limit; the forecaster's own chance of this, stated with the estimate: 35%; at least 2.0-fold (0.30 log units) between middle value and limit.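

Compound 3 and compound 4 are both reported only as limits, so the step between them cannot be read: the limit of > 100000 nM in this assay, at which 3 of the 4 values shown sit.

In this assay the compounds shown leave open whether heptyl in place of hydrogen changes growth inhibition at all.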